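The compounds below may be only part of what the source reports. "The series", "measured", "known", "first", "only" and "open" are said of these compounds alone.

Measured in an ADME assay on microsomes from liver (Canis lupus familiaris) for metabolic stability; a lower number here means slower removal, a higher number faster removal of the compound:
- compound 1 `NC1=N[C@@]2(c3cc(NC(=O)c4cnc(OCF)cn4)ccc3F)COCC[C@H]2CC1(F)F`: 15.5 mL.min-1.g-1
- compound 2 `NC1=N[C@@]2(c3cc(NC(=O)c4cnc(OCF)cn4)ccc3F)CCOC[C@H]2CC1(F)F`: 11.8 mL.min-1.g-1

Compound 1, at 15.5 mL.min-1.g-1, stands within the scatter of compound 2, at 11.8 mL.min-1.g-1. Compound 3 `C[C@H]1C[C@H]2CC(F)(F)C(N)=N[C@@]2(c2cc(NC(=O)c3cnc(OCF)cn3)ccc2F)CO1` departs from compound 1 by one change, methyl in place of hydrogen on a saturated ring carbon, next to the ring oxygen. Among the compounds with values here, no measured step shows what such a methyl does, and no step beyond the scatter is expected in this assay. The estimated change is a 1.0-fold higher number from compound 1 to compound 3 (0.01 log units; within the scatter). For compound 3 the expected value is 16 mL.min-1.g-1, with an estimated range of 8 mL.min-1.g-1 to 30 mL.min-1.g-1.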

Compound 3, intrinsic clearance in microsomes: 18.6 mL.min-1.g-1
Estimate against measurement, compound 3: 1.2-fold (0.07 log units) below; the range from low to high includes it.
By their numbers in this assay, from the lowest: compounds 2, 1 and 3 (each within the scatter of the next).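

In this assay, within the data shown here, methyl in place of hydrogen on a saturated ring carbon, next to the ring oxygen, gives a 1.2-fold higher number from compound 1 to compound 3 (0.08 log units; within the scatter) and so provides the first measured step at this position. This single pair shows that the position carries a methyl without a step beyond the scatter. No measured evidence bears on why the number stays within the scatter.

The compounds shown leave open whether an ethyl, a hydroxymethyl or a fluorine on this carbon would behave as the methyl does. They also leave open whether the same methyl on the core of compound 2 would give a similar step.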